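The source may hold more compounds than are shown below. What is called first, only, known or untested is meant among the compounds shown, and "the series" means these compounds.

Values measured in a functional assay on HUVEC cells (Homo sapiens), read by BrdU incorporation, with a stated time of 72 h (a lower number here means a stronger inhibitor, a higher number a weaker inhibitor), are these:

Compound 1 `Cc1ccc2nc(Cl)c(/C=C/C(=O)c3sccc3C)cc2c1` gives 127 nM
Compound 2 `Cc1ccc2nc(Cl)c(/C=C/C(=O)c3sccc3Cl)cc2c1` gives 37.5 nM
Compound 3 `Cc1csc(C(=O)/C=C/c2cc3cc(C)ccc3nc2Cl)c1` gives 106 nM

All three share one core and differ only in the group on the carbonyl carbon. Compound 3 gives 106 nM and stands level with one of the other two but clearly apart from the other. The numbers show a 1.2-fold lower number from compound 1 to compound 3 (0.08 log units; within the scatter) and so no real difference, then a 2.8-fold higher number from compound 2 to compound 3 (0.45 log units; beyond the scatter) and so a real one.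

The next compound, compound 4 `Cc1ccc2nc(Cl)c(/C=C/C(=O)c3ccc(I)s3)cc2c1`, keeps the shared core and changes that one group: 5-iodothiophen-2-yl in place of 4-methylthiophen-2-yl on a carbonyl carbon. The closest measured change is a 3.4-fold lower number from compound 1 to compound 2 (0.53 log units; beyond the scatter) where chloro took the place of methyl on an aromatic carbon. For the measured compounds named here, compound 4 carries iodo instead of chloro, and no iodo compound has been measured, so this single step is only a rough guide. A modest move towards a lower number seems likely, smaller than that chloro step. In this assay the expected change is therefore a 1.8-fold lower number from compound 3 to compound 4 (0.25 log units; within the scatter) and it may turn out smaller still. The estimated value for compound 4 is 60 nM with an expected range from 20 nM to 180 nM until a measurement settles it.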

Compound 4, half-maximal inhibitory concentration: 129 nM
Estimate against measurement, compound 4: 2.2-fold (0.33 log units) below, within the range that was stated.
By their numbers in this assay, from the lowest: compound 2; then compounds 3, 1 and 4 (each within the scatter of the next).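

In this assay, replacing 4-methylthiophen-2-yl with 5-iodothiophen-2-yl on the carbonyl carbon gives no real shift (a 1.2-fold higher number from compound 3 to compound 4 (0.09 log units; within the scatter)), and compound 4 also stands level with the other methyl compound (a 1.0-fold higher number from compound 1 to compound 4 (0.01 log units; within the scatter)). A halogen on the thiophene is therefore not enough on its own to give a lower number, as compound 4 stays clearly apart from the chloro compound (a 3.4-fold higher number from compound 2 to compound 4 (0.54 log units; beyond the scatter)). Of the four groups at this position, three give numbers within the scatter of the next, and only the 3-chlorothiophen-2-yl group of compound 2 stands apart, so the one earlier gain now rests on that single compound.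

Compounds 2 and 4 differ in both the halogen and its place on the thiophene, and no compound shown separates these two changes. As far as these compounds go, it also stays open how a quite different group on this thiophene, such as an amine or a carboxylic acid, would behave, and no measurement here explains why the chloro compound stands apart.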